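The source may hold more compounds than are shown below. What is called first, only, known or untested is meant among the compounds shown, and "the series" means these compounds.

Compound 1 `Cc1ccc(NC(=O)c2c(O)c3cccnc3n(-c3ccccc3)c2=O)cc1` stands lowest of the three compounds measured in a functional assay on the whole organism for inhibition, with Rattus norvegicus as the target, read by cytopathic effect and paw edema, at a dose of 100 mg/kg by the oral route (a lower number here means less inhibition, a higher number more inhibition at the dose given (going by the name of the read-out)), giving 2.2%. Compound 2 `O=C(Nc1cccc(Cl)c1)c1c(O)c2cccnc2n(-c2ccccc2)c1=O` gives 13.4% and compound 3 `O=C(NCc1ccncc1)c1c(O)c2cccnc2n(-c2ccccc2)c1=O` gives 15.4%. Compound 4 `Cc1cnccc1NC(=O)c1c(O)c2cccnc2n(-c2ccccc2)c1=O` has not yet been measured; it differs from compound 1 in one place: 3-methylpyridin-4-yl in place of 4-methylphenyl on an amide-type nitrogen. Among the compounds with values here, two measured steps bear on this change, since each also replaces the 4-methylphenyl on the amide-type nitrogen: a number 11.2 percentage points higher from compound 1 to compound 2 (beyond the scatter) and a number 13.2 percentage points higher from compound 1 to compound 3 (beyond the scatter). Because a number 13.2 percentage points higher from compound 1 to compound 3 (beyond the scatter) was a modest rise and compound 3, like compound 4, carries a pyridin-4-yl group on that nitrogen, a modest rise is expected for compound 4 as well, a number 9.8 percentage points higher from compound 1 to compound 4 (within the scatter). Compound 4 is therefore estimated to give 12%, with a range from 0% to 28%.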

Compound 4, a percentage reported as inhibition, in the whole organism at one dose (the size of the read-out at that dose, not a potency): 8.8%
Estimate against measurement, compound 4: 3.2 percentage points above; low and high end bracket the measured number.
By their numbers in this assay, from the lowest: compounds 1, 4, 2 and 3 (each within the scatter of the next, the first and the last beyond it).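

In this assay the swap of 4-methylphenyl for 3-methylpyridin-4-yl on the amide-type nitrogen gives a number 6.6 percentage points higher from compound 1 to compound 4 (within the scatter), so this change, unlike the two earlier steps from compound 1, cannot be told apart from scatter. The comparisons with the other amides give a number 6.6 percentage points lower from compound 3 to compound 4 (within the scatter) and a number 4.6 percentage points lower from compound 2 to compound 4 (within the scatter), so compound 4 cannot be separated from any of the other three, although compound 1 and compound 3 stay apart. Nothing measured here explains these numbers.

Still open, going by these compounds, is whether a plain pyridin-4-yl without the methyl, or a longer chain ending in a carboxylic acid, would read differently on that nitrogen.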